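A few compounds are considered here, and "the series" means these few. Any claim that something is new, unique, unknown or untested is made for them only; others in the source may bear on it.

Compound 1 `Cn1c(CN2CCC(c3ccccc3)CC2)nc2ccccc21` is one of three closely related structures tested in a functional assay on CHO cells for agonist activity at metabotropic glutamate receptor 2 (Homo sapiens), read by FLIPR; a higher number here means that more compound is needed for the effect, a lower number that less compound is needed. In this assay compound 1 gives 6310 nM. Compound 3 `Cn1c(CN2CCN(c3ccc(C(F)(F)F)cn3)CC2)nc2ccccc21` gives 6310 nM, the same number as compound 1 at the digits shown, so the two are indistinguishable here. Compound 2 `Cn1c(CN2CCC(c3ccc(Cl)cc3)CC2)nc2ccccc21` gives 5010 nM, and the step of a 1.3-fold lower number from compound 1 to compound 2 (0.10 log units; within the scatter) shows that this small change also leaves the reading where it was, within the scatter. All three compounds therefore sit together.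

Compound 4 `Cn1c(CN2CCC(c3ccccn3)CC2)nc2ccccc21` carries a single change from compound 1: pyridin-2-yl in place of phenyl on a saturated ring carbon. Among the compounds with values here, only one measured step bears on this, the one from compound 1 to compound 2, and it was within the scatter; it concerned a substituent on the phenyl, not an exchange of a ring atom, so it is an indirect guide at best. Compound 3 shows that a ring of this kind elsewhere in the molecule gives the same number as compound 1. The expectation for compound 4 is therefore no step beyond the scatter, a 1.0-fold lower number from compound 1 to compound 4 (0.00 log units; within the scatter), with compound 4 estimated at 6300 nM, between 2500 nM and 16000 nM.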

Compound 4, half-maximal effective concentration: > 15800 nM
Compound 4 was reported as a limit (the forecaster's own chance of this, stated with the estimate: 10%); at least 2.5-fold (0.39 log units) between middle value and limit.
By their numbers in this assay, from the lowest: compounds 2, 1 and 3 (each within the scatter of the next). At a limit, above all of these: compound 4.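

In this assay, compound 4 is reported only as a limit, not as a number: the limit of > 15800 nM in this assay, at which 1 of the 4 values shown sits.

Putting pyridin-2-yl in place of phenyl on the saturated ring carbon gives an at least 2.5-fold higher number from compound 1 to compound 4 (0.39 log units; beyond the scatter), and putting it in place of 4-chlorophenyl gives an at least 3.1-fold higher number from compound 2 to compound 4 (0.49 log units; beyond the scatter). The chloro change on the phenyl stayed within the scatter, so this exchange of one ring carbon for a nitrogen, which also adds a hydrogen-bond acceptor by count, is the first change at this place shown to move the reading beyond the scatter.

On these data alone, the true size of the step stays unknown, since only its lower bound can be read. Also open, as far as these compounds go, is how pyridin-3-yl or pyridin-4-yl would read on the same carbon, and whether a methoxy group or an amine on the phenyl would move the number at all.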